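Fluorophenyl for Methoxyphenyl: a Cytotoxicity Forecast

A few compounds are considered here, and "the series" means these few. Any claim that something is new, unique, unknown or untested is made for them only; others in the source may bear on it.

Compound 1 `O=[N+]([O-])c1ccc(CN2CCC(n3cc(CC(OCc4cc(-c5ccccc5)no4)c4ccc(Br)cc4)nn3)CC2)cc1`, a functional assay on HCT-116 cells (Homo sapiens) for cytotoxicity, with a stated time of 48 h; a lower number here means a stronger inhibitor, a higher number a weaker inhibitor: > 25000 nM (a limit)
Compound 2 `COc1ccc(-c2cc(COC(Cc3cn(C4CCN(Cc5ccc([N+](=O)[O-])cc5)CC4)nn3)c3ccc(Br)cc3)on2)cc1`, this assay: > 25000 nM (a limit)

Compound 2 stands at a limit of this assay, not at a number. The step that the two limits leave unreadable from compound 1 to compound 2 is unreadable, because the limit of > 25000 nM in this assay, at which 2 of the 2 values shown sit, holds both measured values. Compound 3 `O=[N+]([O-])c1ccc(CN2CCC(n3cc(CC(OCc4cc(-c5cccc(F)c5)no4)c4ccc(Br)cc4)nn3)CC2)cc1` differs by 3-fluorophenyl in place of 4-methoxyphenyl on an aromatic carbon. Within the data shown here, no measured step bears on this change, so compound 3 is expected to sit at the same limit, an estimated step that the limit leaves unreadable from compound 2 to compound 3. The estimate for compound 3 is 35000 nM, from 12000 nM to 100000 nM.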

Compound 3, half-maximal inhibitory concentration: 6000 nM
Compound 3: middle estimate off by 5.8-fold (0.77 log units), on the high side, outside the stated range (below it).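

In this assay, 3-fluorophenyl in place of 4-methoxyphenyl gives an at least 4.1-fold lower number from compound 2 to compound 3 (0.61 log units; beyond the scatter), and fluoro in place of hydrogen alone gives an at least 4.1-fold lower number from compound 1 to compound 3 (0.61 log units; beyond the scatter), so a change on this phenyl group can bring a compound out of the limit. Both sizes are lower bounds only, because compound 1 and compound 2 each sit at a limit: the limit of > 25000 nM in this assay, at which 2 of the 3 values shown sit.

The compounds shown leave open whether 4-fluorophenyl would match 3-fluorophenyl. They also leave open whether an amine or a nitrile on that phenyl group would keep this gain.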